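The source may hold more compounds than are shown below. What is called first, only, known or untested is meant among the compounds shown, and "the series" means these compounds.

In a functional assay on PC-3 cells (Homo sapiens) for cytotoxicity, read by MTT assay, with a stated time of 72 h (on this read-out lower numbers stand for stronger inhibition and higher numbers for weaker inhibition), the values so far:
compound 1 `COCOc1cc(/C=C/C(=O)OCC(=O)NN2CCOCC2)ccc1OCc1ccccc1`: a limit only, > 200000 nM.
compound 2 `O=C(COC(=O)/C=C/c1ccc(O)c(O)c1)NN1CCOCC1`: a limit only, > 200000 nM.
compound 3 `COc1ccc(NC(=O)COC(=O)/C=C/c2cc(OC)c(OCc3ccccc3)c(OC)c2)cc1`: a limit only, > 200000 nM.

Compound 2 thus stands at the limit, not at a number, and nothing separates it from the other two, since all three share (the limit of > 200000 nM in this assay, at which 3 of the 3 values shown sit). Compound 4 `COc1ccc(NC(=O)COC(=O)/C=C/c2ccc(O)c(O)c2)cc1` differs from compound 2 by 4-methoxyphenyl in place of morpholin-4-yl on an amide-type nitrogen. Within the data shown here, no measured step covers this change. Compound 3 carries the same 4-methoxyphenyl amide and likewise gives only a limit, > 200000 nM. On that basis no move beyond the scatter is expected in this assay, in either direction. Compound 4 is expected to stay at the limit, around 300000 nM with a range of 100000 nM to 1000000 nM. The expected step is therefore a step that the limit leaves unreadable from compound 2 to compound 4.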

Compound 4, half-maximal inhibitory concentration: 172000 nM
Beside the measured number, compound 4's estimate is 1.7-fold (0.24 log units) above it; the range from low to high includes it.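

In this assay, among these compounds, 4-methoxyphenyl in place of morpholin-4-yl on an amide-type nitrogen gives an at least 1.1-fold lower number from compound 2 to compound 4 (0.06 log units; that floor lies within the scatter), so this position can yield a measured number, which none of the earlier compounds did. Compound 4 is the only compound shown that is not at a limit. The true size of the step stays unreadable because compound 2 has only a limit: the limit of > 200000 nM in this assay, at which 3 of the 4 values shown sit.

Whether the position tolerates other groups remains open, since a carboxylic acid or a longer alkyl chain on this nitrogen does not appear among the compounds shown. Going by these compounds, whether any such group would give a clearly lower number also remains open.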